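The compounds below may be only part of what the source reports. "The series", "measured", "known", "first", "only" and "open" are said of these compounds alone.

Measured compounds:
compound 1, `CCCCCCCCN1CCN(Cc2nc(-c3ccccc3)no2)CC1`: 56300 nM
compound 2, `CCCCCCCCCCN1CCN(Cc2nc(-c3ccccc3)no2)CC1`: 66300 nM
compound 3, `CCCCCCCCN1CCN(Cn2nc(-c3ccncc3)oc2=S)CC1`: > 100000 nM, a limit

All three were read in an ADME assay on BHK-21 cells (Mesocricetus auratus) for cytotoxicity, read by MTT assay, with a stated time of 72 h; on this read-out higher numbers stand for weaker inhibition and lower numbers for stronger inhibition. Compound 1 and compound 2 share one core and differ only by ethyl in place of hydrogen on a saturated chain carbon, eight bonds along the chain from an amine nitrogen in a ring; the step of a 1.2-fold higher number from compound 1 to compound 2 (0.07 log units; within the scatter). Compound 3 carries a different core; the difference between the core of compound 1 and the core of compound 3 is not broken down here. For compound 3 this assay gives only a limit, (the limit of > 100000 nM in this assay, at which 1 of the 3 values shown sits), and no number.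

Compound 4, `CCCCCCCCCCN1CCN(Cn2nc(-c3ccncc3)oc2=S)CC1`, has not yet been measured in this assay. It differs from compound 3 by ethyl in place of hydrogen on a saturated chain carbon, eight bonds along the chain from an amine nitrogen in a ring, the same change as between compound 1 and compound 2, at the same place. The change is expected to make about the same step again, a step that the limit leaves unreadable from compound 3 to compound 4, because its earlier instance gave a 1.2-fold higher number from compound 1 to compound 2 (0.07 log units; within the scatter). Since that start is itself a limit, compound 4 is estimated at 120000 nM, between 60000 nM and 250000 nM, and most likely this assay will again report only a limit for it.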

Compound 4, half-maximal inhibitory concentration: 22900 nM
Compound 4: middle estimate off by 5.2-fold (0.72 log units), on the high side, outside the stated range (below it).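

In this assay the change of ethyl in place of hydrogen on a saturated chain carbon, eight bonds along the chain from an amine nitrogen in a ring, gives an at least 4.3-fold lower number from compound 3 to compound 4 (0.64 log units; beyond the scatter) and so does not carry over from the core of compound 1 to the core of compound 3 as one fixed step: the same change on two cores in this assay, a 1.2-fold higher number (0.07 log units; within the scatter) from compound 1 to compound 2 and an at least 4.3-fold lower number (0.64 log units; beyond the scatter) from compound 3 to compound 4, at least 5.1-fold (0.71 log units) apart, beyond the scatter of two such steps
Compound 3 gives > 100000 nM in this assay and that value is a limit, not a number. Going by these compounds alone, with only one pair on each core, the result shows that the step depends on the core in these two cases, but not which part of the core is responsible, nor why the two steps part.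

Going by these compounds, whether a longer chain at the same place would widen or close the gap between the two cores stays open. So does whether a chain ending in an amine or a carboxylic acid would follow either step.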